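A few compounds are considered here, and "the series" means these few. Any claim that something is new, unique, unknown or untested is made for them only; others in the source may bear on it.

Measured so far:
- compound 1 `COc1ccc(C2CC(c3ccccc3)=NN2C(=O)c2ccco2)cc1`: 27300 nM
- compound 2 `O=C(c1ccncc1)N1N=C(c2ccc(Cl)cc2)CC1c1ccco1`: 7900 nM

In a functional assay on T47D cells (Homo sapiens) for antiproliferative activity, read by CCK-8 assay, with a stated time of 72 h (on this read-out lower numbers stand for stronger inhibition and higher numbers for weaker inhibition), compound 1 gives 27300 nM, the higher of the two numbers, and so the weaker inhibition; compound 2 gives 7900 nM, lower by more than the usual scatter. Compound 3 `COc1ccc(C2CC(c3ccccc3)=NN2C(=O)c2nc3ccccc3s2)cc1` keeps the core of compound 1 but carries 1,3-benzothiazol-2-yl in place of furan-2-yl on a carbonyl carbon. For the measured compounds named here, no measured pair shows this change, so any forecast is uncertain. A modest move toward a lower number in this assay is expected, namely a 2.3-fold lower number from compound 1 to compound 3 (0.36 log units; beyond the scatter). Compound 3 is estimated at 12000 nM, with an expected range of 4000 nM to 35000 nM.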

Compound 3, half-maximal inhibitory concentration: > 50000 nM
Compound 3: no number, only a limit; the forecaster's own chance of this, stated with the estimate: 8%; at least 4.1-fold (0.61 log units) between middle value and limit.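

In this assay compound 3 reads > 50000 nM, which is a limit of the assay and not a number. From the compounds shown here alone, on this carbonyl carbon, 1,3-benzothiazol-2-yl brings no gain over furan-2-yl, since the change gives an at least 1.8-fold higher number from compound 1 to compound 3 (0.26 log units; that floor lies within the scatter), and the true size of the step stays unknown. The comparison therefore rests on a limit, not on a second number: the limit of > 50000 nM in this assay, at which 1 of the 3 values shown sits.

Going by these compounds, whether thiophen-2-yl or a plain ethyl chain at this place would give a lower number in this assay stays open. So does how far compound 3 really lies from compound 1.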